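Cytotoxicity limits and a methoxy step in the series

A few compounds are considered here, and "the series" means these few. Any claim that something is new, unique, unknown or untested is made for them only; others in the source may bear on it.

Measured in an ADME assay on MT4 cells (Homo sapiens) for cytotoxicity, read by MTT assay (a higher number here means that more compound is tolerated, a lower number that less compound is tolerated), all values being limits:
- compound 1 `Cc1c(Cc2c(Cl)cccc2Cl)nc(SCC(=O)c2ccccc2)[nH]c1=O`: > 60000 nM
- compound 2 `COc1ccc(C(=O)CSc2nc(Cc3c(Cl)cccc3Cl)c(C)c(=O)[nH]2)cc1`: > 56000 nM
- compound 3 `Cc1c(Cc2c(F)cccc2Cl)nc(SCC(=O)c2ccccc2)[nH]c1=O`: > 12000 nM

Compound 3 stands at a limit, (the limit of > 12000 nM in this assay, at which 1 of the 3 values shown sits), so it offers no number to start from. Compound 4 `COc1ccc(C(=O)CSc2nc(Cc3c(F)cccc3Cl)c(C)c(=O)[nH]2)cc1` differs from it as follows: methoxy in place of hydrogen on an aromatic carbon. This is methoxy in place of hydrogen on an aromatic carbon, para to a large group, or phenyl to 4-methoxyphenyl.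

The same change has been measured once, as a step that the two limits leave unreadable from compound 1 to compound 2. Compound 1 and compound 2 thus give no size or direction for it. The other measured step, a step that the two limits leave unreadable from compound 1 to compound 3, concerns fluoro in place of chloro and gives no size either. With no readable step to carry over, no shift beyond the scatter is expected in this assay, and no direction is favoured. The expected step is a step that the limit leaves unreadable from compound 3 to compound 4. A limit is again the likeliest report. For compound 4 the estimated value is 20000 nM, with an expected range of 11000 nM to 60000 nM.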

Compound 4, half-maximal cytotoxic concentration: > 12000 nM
Compound 4 gave a limit, no number; the forecaster's own chance of this, stated with the estimate: 85%; the middle value is on the limit's open side.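

The steps from compound 3 to compound 4 and from compound 2 to compound 4 cannot be read in this assay, as all their values are limits. The compounds shown leave open the size and direction of both the methoxy and the fluoro change.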